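The source may report more compounds than this note shows. Statements on the series, on what has been measured and on what is new or still open speak of the compounds shown alone.

Going by the values given here, compound 1, `CCCCCCCCCCCCCCC[C@@H](O)[C@@H](N)[C@@H](C)O`, is the weaker of the two compounds measured so far: in a functional assay on T47D cells (Homo sapiens) for antiproliferative activity, read by sulforhodamine B assay, with a stated time of 48 h (a higher number here means a weaker inhibitor of growth, a lower number a stronger inhibitor of growth), compound 1 gives 19000 nM, the highest number of the pair. Compound 2, `CCCCCCCCCCCCCCC[C@@H](O)[C@H](C)N`, gives 900 nM in this assay. Among the compounds with values here, the one step measured between them, a 21-fold lower number from compound 1 to compound 2 (1.32 log units; beyond the scatter), comes from placing methyl in place of 1-hydroxyethyl on a saturated chain carbon bound to an amine nitrogen and a saturated chain carbon, so that the hydroxy of that side arm is gone.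

Compound 3, `CCCCCCCCCCCCCCC[C@@H](O)[C@@H](N)[C@@H](C)CC`, is the next member. It differs from compound 1 by ethyl in place of hydroxy on a saturated chain carbon bound to two saturated chain carbons. That step shares with the measured one the loss of the hydroxy, while the carbon count of the side arm grows rather than shrinks. Within the data shown here, only the step from compound 1 to compound 2 bears on it, and that step was large. A lower number than compound 1 is therefore expected, likely smaller in size than a 21-fold lower number from compound 1 to compound 2 (1.32 log units; beyond the scatter), since the loss of hydroxy is the common element. The expected step is a 7.6-fold lower number from compound 1 to compound 3 (0.88 log units; beyond the scatter), and compound 3 is estimated at 2500 nM, with a range from 600 nM to 10000 nM.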

Compound 3, concentration for 50% growth inhibition: 17000 nM
Compound 3: middle estimate off by 6.8-fold (0.83 log units), on the low side; measured number outside the range, above it.
By their numbers in this assay, from the lowest: compound 2; then compounds 3 and 1 (each within the scatter of the next).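

In this assay, ethyl in place of hydroxy on a saturated chain carbon bound to two saturated chain carbons gives a 1.1-fold lower number from compound 1 to compound 3 (0.05 log units; within the scatter) and so leaves no readable difference, which shows that the exchange of this hydroxy for ethyl does not by itself reproduce the large step seen with compound 2. Sec-butyl in place of methyl on a saturated chain carbon bound to an amine nitrogen and a saturated chain carbon gives a 19-fold higher number from compound 2 to compound 3 (1.28 log units; beyond the scatter), so among these three compounds only the methyl of compound 2 stands apart, while the 1-hydroxyethyl of compound 1 and the sec-butyl of compound 3 stay together. Nothing available alongside these numbers gives a reason for this grouping.

On these data alone, whether the number follows the size of the arm on that carbon or something particular to methyl remains open, and an ethyl or isopropyl arm there would sit directly between these cases. Also open, as far as these compounds go, is whether a 1-methoxyethyl arm would stay with compound 1 and compound 3.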